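The source may report more compounds than this note shows. Statements on the series, on what has been measured and on what is new or still open speak of the compounds shown alone.

Compound 1 `C/C(=C\CC/C(C)=C/CC[C@@H]1[C@@]2(C)CCC(=O)C(C)(C)[C@H]2CC[C@@]1(C)O)CC/C=C(\C)C(=O)OCc1cn(-c2ccccc2Br)nn1` belongs to a series in which a long chain ester is joined to a five-membered aromatic ring with three nitrogen atoms, on one of which an aryl group sits. In a functional assay on A549 cells (Homo sapiens) for antiproliferative activity, read by MTT assay, with a stated time of 48 h (a higher number here means a weaker inhibitor, a lower number a stronger inhibitor), compound 1 gives > 150000 nM, which is a limit of the assay rather than a measured number. Compound 2 `C/C(=C\CC/C(C)=C/CC[C@@H]1[C@@]2(C)CCC(=O)C(C)(C)[C@H]2CC[C@@]1(C)O)CC/C=C(\C)C(=O)OCc1cn(-c2ccccc2F)nn1` differs from compound 1 by fluoro in place of bromo on an aromatic carbon. In this assay compound 2 gives > 150000 nM, again a limit of the assay. The step that the two limits leave unreadable from compound 1 to compound 2 therefore cannot be read in size or direction, and the limit of > 150000 nM in this assay, at which 2 of the 2 values shown sit, is all that is known for this pair. Compound 3 `C/C(=C\CC/C(C)=C/CC[C@@H]1[C@@]2(C)CCC(=O)C(C)(C)[C@H]2CC[C@@]1(C)O)CC/C=C(\C)C(=O)OCc1cn(-c2ccc(C(C)(C)C)cc2)nn1` has not yet been measured; relative to compound 1 the change is 4-(tert-butyl)phenyl in place of 2-bromophenyl on an aromatic nitrogen. Within the data shown here, no measured step shows how changing the aryl group on this aromatic nitrogen moves potency, since both measured compounds sit at the same limit. Compound 3 is therefore expected to give 200000 nM in this assay, within 60000 nM to 600000 nM. The step that the limit leaves unreadable from compound 1 to compound 3 is estimated to stay within the scatter.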

Compound 3, half-maximal inhibitory concentration: > 150000 nM
Compound 3 was reported as a limit; the forecaster's own chance of this, stated with the estimate: 75%; the middle value does not contradict the limit.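

Compound 3, like compound 1 and compound 2, is reported in this assay only as a limit, so no step among these three compounds can be read in size or direction: the limit of > 150000 nM in this assay, at which 3 of the 3 values shown sit. The compounds shown leave open how the aryl group on this aromatic nitrogen affects potency, if it does at all.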